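This account rests on a few compounds, and the source may have more. Where it says the series, first, only, none or still open, it means among the compounds named here.

Measured in a functional assay with Oryctolagus cuniculus as the target; on this read-out higher numbers stand for weaker inhibition and lower numbers for stronger inhibition; each entry is a limit and not a number:
compound 1 `COc1ccc(-c2nc(/N=C(\N)NC(C)C)sc2-c2ccc(OC)cc2)cc1`: > 100 nM
compound 2 `COc1ccc(-c2nc(/N=C(\N)N3CCOCC3)sc2-c2ccc(OC)cc2)cc1`: < 1000 nM
compound 3 `COc1ccc(-c2nc(CN)sc2-c2ccc(OC)cc2)cc1`: > 100 nM

Compound 3 has no numerical value, only the limit > 100 nM. The other two compounds are also known only through limits, so its rank within the series cannot be read. The values fall at two limits: the limit of > 100 nM in this assay, at which 2 of the 3 values shown sit, and (the limit of < 1000 nM in this assay, at which 1 of the 3 values shown sits).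

Compound 4 `COc1ccc(-c2nc(CNC(=O)CSc3ccccc3)sc2-c2ccc(OC)cc2)cc1` carries ((phenylsulfanyl)methyl)carbonyl in place of hydrogen on an amine nitrogen.

Two measured steps change the group on an aromatic carbon that compound 3 carries: a step that the two limits leave unreadable from compound 1 to compound 3 and a step that the limit leaves unreadable from compound 2 to compound 3. A third, a step that the limit leaves unreadable from compound 1 to compound 2, exchanges isopropylamino for morpholin-4-yl. None of the three has a readable size, and none places a group on the amine nitrogen of compound 3. The measured steps therefore give neither a size nor a direction for the new change in this assay.

The expected step that the limit leaves unreadable from compound 3 to compound 4 is correspondingly uncertain and rests mainly on the limit of compound 3, > 100 nM. For compound 4 the estimated value is 300 nM, with an expected range of 40 nM to 3000 nM.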

Compound 4, half-maximal inhibitory concentration: < 100 nM
Compound 4 gave a limit, no number (the forecaster's own chance of this, stated with the estimate: 50%); middle value at least 3.0-fold (0.47 log units) away from the limit.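

Going by these compounds alone, on the amine nitrogen whose other neighbour is a saturated chain carbon, ((phenylsulfanyl)methyl)carbonyl in place of hydrogen gives the first step with a readable direction in this assay: a number no higher from compound 3 to compound 4 (the limit leaves the size open). Compound 4 is known only through a limit, < 100 nM, and the series shows no other value at that limit. This is also the first change shown on this nitrogen, and it shows that the position can carry an acyl group of this size without the read-out moving towards weaker inhibition, whereas the earlier steps among compound 1, compound 2 and compound 3 cannot be read and none of them places a group there.

From the compounds shown here alone, the size of the step remains open, since neither end of it is a number. The compounds shown also do not separate the parts of the new group: a plain acetyl on the same nitrogen, or a phenoxyacetyl with oxygen in place of the sulfur, would show whether the carbonyl, the sulfur or the phenyl ring goes with the change.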